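Fluoro for methoxy on a growth inhibitor

The source may hold more compounds than are shown below. What is called first, only, known or untested is meant among the compounds shown, and "the series" means these compounds.

Measured so far in a functional assay on DU-145 cells (Homo sapiens) for antiproliferative activity, read by sulforhodamine B assay, with a stated time of 48 h; a lower number here means a stronger inhibitor of growth, a higher number a weaker inhibitor of growth (two compounds)
Compound 1 `CCCNc1nc(Nc2ccc(OC)cc2)nc2ccccc12` gives 4080 nM
Compound 2 `COc1ccc(Nc2nc(NC3CC3)c3ccccc3n2)cc1` gives 13000 nM

Compound 1 holds the lower of the two numbers. Among the compounds with values here, the one measured step is a 3.2-fold higher number from compound 1 to compound 2 (0.50 log units; beyond the scatter) and it concerns the group on a nitrogen, not the place changed next. Compound 3 `CCCNc1nc(Nc2ccc(F)cc2)nc2ccccc12` carries the change fluoro in place of methoxy on an aromatic carbon with fluoro in place of methoxy on an aromatic carbon, para to a large group. Within the data shown here, no measured step tests this swap, so its direction stays open. That single step from compound 1 serves only as a rough guide to size, and in this assay a move no larger is expected, possibly none beyond the scatter. The estimated step is a 1.2-fold higher number from compound 1 to compound 3 (0.09 log units; within the scatter) with a slight lean toward a higher number. Compound 3 is expected to give about 5000 nM in this reading (1800 nM to 14000 nM).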

Compound 3, concentration for 50% growth inhibition: 4200 nM
For compound 3 the middle estimate is 1.2-fold (0.08 log units) above the measured one; measured number inside the range.
By their numbers in this assay, from the lowest: compounds 1 and 3 (each within the scatter of the next); then compound 2.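

In this assay, fluoro in place of methoxy on the aromatic carbon para to a large group gives a 1.0-fold higher number from compound 1 to compound 3 (0.01 log units; within the scatter). Within the data shown here, the earlier compounds had tested only the group on a nitrogen, and this is the first reading at the aromatic position: the group there went from two heavy atoms to one, and from one hydrogen-bond acceptor to none, with no change beyond the scatter. No independent measurement is available to explain why compound 1 and compound 3 read alike.

The compounds shown leave open whether a larger or charged group at this position, such as a dimethylamino group or a carboxylic acid, would also leave the number unchanged. They also leave open whether fluoro in place of methoxy would read the same alongside the cyclopropyl group of compound 2.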